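Methyl to methoxy on the side chain of compound 1

This account rests on a few compounds, and the source may have more. Where it says the series, first, only, none or still open, it means among the compounds named here.

Three compounds of the shared core have numbers in an in vitro assay on 293-EBNA cells for binding affinity to corticotropin-releasing factor receptor 1 (Homo sapiens); on this read-out lower numbers stand for stronger inhibition and higher numbers for weaker inhibition. Compound 1 `CCC(COC)N(C)c1nc(C)nc2c1nnn2-c1ccc(C(C)C)cc1Br` gives 11.2 nM. Compound 3 `CCCC(CCC)Nc1nc(C)nc2c1nnn2-c1ccc(Br)cc1Br` gives 0.8 nM, the lowest of the three. Compound 2 `COCCNc1nc(C)nc2c1nnn2-c1c(C)cc(C)cc1C` gives 1200 nM, the highest. Compound 1 therefore stands second highest: compound 3 is its nearer neighbour, with the lower number, and compound 2 lies furthest away, with the higher number; both gaps are beyond the scatter. Among the measured compounds shown here, compounds 2 and 3 each differ from compound 1 in more than one place, so no single step between measured compounds can be read off.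

Compound 4 `COCC(COC)N(C)c1nc(C)nc2c1nnn2-c1ccc(C(C)C)cc1Br` is the next compound to be measured in this assay. It differs from compound 1 in one place: methoxy in place of methyl on a saturated chain carbon, two bonds along the chain from a nitrogen on an aromatic ring. The rest of the molecule is unchanged. For the measured compounds named here, no measured pair shows this change on its own. Going by the values given here, compound 2, the only other compound carrying a methoxy on its chain, gives 1200 nM, but it differs in several further places and does not isolate the change. The expected step from compound 1 to compound 4 is a 1.8-fold higher number from compound 1 to compound 4 (0.25 log units; within the scatter), a small move toward a higher number that may not clear the scatter. For compound 4 the estimate in this assay is 20 nM, with a range from 6 nM to 70 nM.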

Compound 4, inhibition constant: 21.3 nM
For compound 4 the middle estimate is 1.1-fold (0.03 log units) below the measured one; measured number inside the range.
By their numbers in this assay, from the lowest: compound 3; then compounds 1 and 4 (each within the scatter of the next); then compound 2.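

In this assay the series now has its first change in a single place, and the step is a 1.9-fold higher number from compound 1 to compound 4 (0.28 log units; within the scatter) for methoxy in place of methyl on a saturated chain carbon, two bonds along the chain from a nitrogen on an aromatic ring. At this position, therefore, the methoxy with its oxygen and hydrogen-bond acceptor gives no difference that can be told from the scatter, and 1-(methoxymethyl)propyl and 2-methoxy-1-(methoxymethyl)ethyl cannot be ranked on this read-out. No other kind of measurement bears on this result, so the numbers offer no account of it.

As far as these compounds go, how far this position accepts other groups remains open: an amine, a carboxylic acid or a longer chain on the same carbon could read close to the methoxy pair or well away from it. Among the compounds shown here, it is also open whether the same methyl-to-methoxy change would give a step of similar size on a side chain of another shape, or with different substituents on the aromatic ring, since only this one matched pair is available.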